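Moving the bromine from compound 2 to compound 3

The source may hold more compounds than are shown below. What is called first, only, known or untested is meant among the compounds shown, and "the series" means these compounds.

- compound 1 `OC[C@H]1O[C@@H](n2cnc3c(NCc4ccc(Cl)cc4)ncnc32)[C@H](O)[C@@H]1O` gives > 166000 nM (a limit)
- compound 2 `OC[C@H]1O[C@@H](n2cnc3c(NCc4cccc(Br)c4)ncnc32)[C@H](O)[C@@H]1O` gives > 166000 nM (a limit)

In an ADME assay on NIH3T3 cells (Mus musculus) for cytotoxicity, with a stated time of 72 h (a higher number here means a weaker inhibitor, a lower number a stronger inhibitor), compound 2 stands at > 166000 nM as a limit of the assay, not a number. Among the compounds with values here, the only measured step is a step that the two limits leave unreadable from compound 1 to compound 2 and it puts 3-bromophenyl in place of 4-chlorophenyl. The change to compound 3 `OC[C@H]1O[C@@H](n2cnc3c(NCc4ccc(Br)cc4)ncnc32)[C@H](O)[C@@H]1O` is 4-bromophenyl in place of 3-bromophenyl on a saturated chain carbon bound to a nitrogen on an aromatic ring and it puts 4-bromophenyl in place of 3-bromophenyl on a saturated chain carbon bound to a nitrogen on an aromatic ring. Compound 1 and compound 2 both sit at the limit of > 166000 nM in this assay, at which 2 of the 2 values shown sit, so no step beyond the scatter is expected in this assay in either direction. The expected step is a number no higher from compound 2 to compound 3 (the limit leaves the size open) in this estimate. For compound 3 the estimated value is 166000 nM with an expected range from 100000 nM to 300000 nM and most likely only a limit will be reported.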

Compound 3, half-maximal inhibitory concentration: > 166000 nM
Compound 3 ended at the assay's limit; the forecaster's own chance of this, stated with the estimate: 90%; the middle value lies on the limit itself.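

In this assay, within the data shown here, compound 1, compound 2 and compound 3 all end at a limit rather than a number, so no step among them can be read: the limit of > 166000 nM in this assay, at which 3 of the 3 values shown sit. On these data alone, whether these three truly differ stays open.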